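Swapping a hydroxybenzyl arm for a furylmethyl one

The compounds below may be only part of what the source reports. "The series", "measured", "known", "first", "only" and "open" are said of these compounds alone.

Compound 1 `CCCSc1nc(N/N=C(\C)c2ccccc2O)c2nnn(Cc3ccc(O)cc3)c2n1` holds the lower of the two numbers recorded so far: in a functional assay on MCF7 cells (Homo sapiens) for antiproliferative activity, read by MTT assay, with a stated time of 72 h (on this read-out higher numbers stand for weaker inhibition and lower numbers for stronger inhibition), compound 1 gives 9520 nM. Compound 2 `CCCSc1nc(N/N=C(\C)c2ccccc2)c2nnn(Cc3ccccc3)c2n1` gives 32100 nM in this assay, a higher number that lies beyond the usual scatter. Compound 3 `CCCSc1nc(N/N=C(\C)c2ccccc2O)c2nnn(Cc3ccco3)c2n1` differs from compound 1 in a single place: furan-2-yl in place of 4-hydroxyphenyl on a saturated chain carbon bound to an aromatic nitrogen. For the measured compounds named here, no measured pair isolates this change, so only a modest shift toward weaker inhibition is expected, close to the edge of the scatter. The expected step is a 1.6-fold higher number from compound 1 to compound 3 (0.20 log units; within the scatter). Compound 3 is estimated at 15000 nM, within 5000 nM to 45000 nM.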

Compound 3, half-maximal inhibitory concentration: 29000 nM
Beside the measured number, compound 3's estimate is 1.9-fold (0.29 log units) below it; the range from low to high includes it.
By their numbers in this assay, from the lowest: compound 1; then compounds 3 and 2 (each within the scatter of the next).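

Changing 4-hydroxyphenyl to furan-2-yl brings a 3.0-fold higher number from compound 1 to compound 3 (0.48 log units; beyond the scatter) in this assay and gives the first direct sign that activity depends on the ring at this position. The step cannot separate the loss of the hydrogen-bond donor from the change in ring size, since both change together. Nothing available explains the shift.

Still open, as far as these compounds go, is how a 4-aminobenzyl or pyridin-3-ylmethyl arm on the same core would compare with compound 1. A longer chain between the ring and the aromatic nitrogen is also an open case.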